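The compounds below may be only part of what the source reports. "The series", "measured", "known", "first", "only" and "open" are said of these compounds alone.

Working notes on the series. Among the compounds with values here, in a functional assay on Bel-7402 cells (Homo sapiens) for antiproliferative activity, read by MTT assay, with a stated time of 72 h (on this read-out lower numbers stand for stronger inhibition and higher numbers for weaker inhibition), compound 2 (`COc1ccc(Cn2c(C(=O)O)c(CNCc3cccc(OC)c3)c3ccccc32)cc1`) gives 52900 nM, the only actual number so far. Compound 1 (`COc1ccc(Cn2c(C(=O)O)c(CNCc3cccc(O)c3)c3ccccc32)cc1`) reads > 50000 nM, which is a limit and not a number. Compound 3 (`COc1ccc(Cn2c(C(=O)O)c(CNCc3cccc(OC)c3)c3ccc(C(F)(F)F)cc32)cc1`) reads > 50000 nM, also a limit. Within the data shown here, the position of compound 2 is therefore hard to define: the series so far comes down to the limit of > 50000 nM in this assay, at which 2 of the 3 values shown sit, and its one number lies close to that limit.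

The next compound is compound 4 (`COc1cccc(CNCc2c(C(=O)O)n(Cc3ccc(F)cc3)c3ccccc23)c1`). Relative to compound 2 it carries fluoro in place of methoxy on an aromatic carbon, para to a large group, turning 4-methoxybenzyl into 4-fluorobenzyl: fluoro in place of methoxy on an aromatic carbon.

Two measured steps are available, a step that the limit leaves unreadable from compound 1 to compound 2 and a step that the limit leaves unreadable from compound 2 to compound 3. Neither has a readable size, and neither touches the methoxy that leaves here, so they give no size or direction for this change. With nothing else to go on, the value of compound 2 at 52900 nM serves as the anchor, and no shift beyond the scatter is expected in this assay. The expected change is a 1.2-fold lower number from compound 2 to compound 4 (0.07 log units; within the scatter), and a reading reported only as a limit would be no surprise. For compound 4 the estimate is 45000 nM, with an expected range of 18000 nM to 110000 nM.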

Compound 4, half-maximal inhibitory concentration: > 50000 nM
Compound 4: only a limit was reported; the forecaster's own chance of this, stated with the estimate: 55%; at least 1.1-fold (0.04 log units) between middle value and limit.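

In this assay compound 4 gives > 50000 nM, which is a limit and not a number, so no new step can be read from compound 2 to compound 4. The compounds shown leave open whether fluoro in place of methoxy shifts the number at all, and the series still comes down to a single mark: the limit of > 50000 nM in this assay, at which 3 of the 4 values shown sit.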